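Hydrogen for methyl on the nitrogen of compound 1

The source may hold more compounds than are shown below. What is called first, only, known or untested is meant among the compounds shown, and "the series" means these compounds.

Going by the values given here, in a functional assay on MV4-11 cells (Homo sapiens) for inhibition, read by resazurin assay, with a stated time of 72 h (a lower number here means a stronger inhibitor of growth, a higher number a weaker inhibitor of growth), compound 1 `COc1ccc(N(C)c2nccc(-c3cn(C)c4ccccc34)n2)c(OC)c1` gives 2000 nM, at the top of the three numbers so far. Compound 2 `COCCOc1nc(C)c(-c2ccnc(Nc3ccc(OC)cc3OC)n2)s1` gives 1980 nM, within the scatter of compound 1. Compound 3 `CNc1nc(C)c(-c2ccnc(Nc3ccc(OC)cc3OC)n2)s1` gives 300 nM, clearly lower than both.

Compound 4 `COc1ccc(Nc2nccc(-c3cn(C)c4ccccc34)n2)c(OC)c1` differs from compound 1 by hydrogen in place of methyl on a nitrogen on an aromatic ring.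

Among the compounds with values here, the single measured step, a 6.6-fold lower number from compound 2 to compound 3 (0.82 log units; beyond the scatter), is methylamino in place of 2-methoxyethoxy on an aromatic carbon, so it changes a different place. It bears on the new change only through its size, which is modest. Within the data shown here, no measured pair isolates the methyl on that nitrogen. Compounds 2 and 3 both carry hydrogen on the matching nitrogen, but on a different core, and they give mixed evidence. Compound 3 at 300 nM points towards a lower number, while compound 2 at 1980 nM goes against that.

A modest move to a lower number in this assay is therefore expected, though no change beyond the scatter remains possible. The expected step is a 4.4-fold lower number from compound 1 to compound 4 (0.65 log units; beyond the scatter). The estimate for compound 4 is 450 nM, with an expected range of 110 nM to 1800 nM.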

Compound 4, concentration for 50% growth inhibition: 3410 nM
For compound 4 the middle estimate is 7.6-fold (0.88 log units) below the measured one; the measured number lies above the stated range.
By their numbers in this assay, from the lowest: compound 3; then compounds 2, 1 and 4 (each within the scatter of the next).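

In this assay, going by these compounds alone, the one pair that isolates the methyl on this nitrogen gives a 1.7-fold higher number from compound 1 to compound 4 (0.23 log units; within the scatter), so on the core of compound 1 hydrogen in place of methyl on a nitrogen on an aromatic ring leaves the growth-inhibition number within the usual scatter, and this exchange, which removes one carbon, has no readable effect here. Within the data shown here, the hydrogen that compounds 2 and 3 carry on the matching nitrogen therefore gives no guidance for this core, and only the pair of compound 1 and compound 4 speaks to this position. Nothing measured on these compounds offers an explanation for why the exchange leaves the number within the scatter.

Still open, from the compounds shown here alone, is whether a larger group on this nitrogen, such as ethyl, a longer chain ending in an amine, or acetyl, would keep the number within the scatter of compound 1 or move it clearly in either direction. Also open, going by these compounds, is whether the same exchange behaves alike on the core of compound 3, where methyl on the matching nitrogen would give the direct comparison for this position.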